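Two Fluorophenyl Triazoles and an Untested Methoxyphenyl Analogue

The source may report more compounds than this note shows. Statements on the series, on what has been measured and on what is new or still open speak of the compounds shown alone.

Measured in a functional assay on SGC-7901 cells (Homo sapiens) for inhibition, read by MTT assay, with a stated time of 24 h; on this read-out lower numbers stand for stronger inhibition and higher numbers for weaker inhibition:
Compound 1 (`CC1(C)[C@H]2CC[C@]1(C)N(Cc1cn(-c3ccccc3F)nn1)C(=O)C2`): 300 nM
Compound 2 (`CC1(C)[C@H]2CC[C@]1(C)N(Cc1cn(-c3ccc(F)cc3)nn1)C(=O)C2`): 500 nM

Compound 2 stands at 500 nM and cannot be told apart from compound 1 at 300 nM on these numbers. Within the data shown here, the only measured step is a 1.7-fold higher number from compound 1 to compound 2 (0.22 log units; within the scatter). Compound 3 (`COc1ccccc1-n1cc(CN2C(=O)C[C@@H]3CC[C@@]2(C)C3(C)C)nn1`) has not yet been measured. It differs from compound 2 as follows: 2-methoxyphenyl in place of 4-fluorophenyl on an aromatic nitrogen. In words, 2-methoxyphenyl stands in place of 4-fluorophenyl on an aromatic nitrogen. Among the measured compounds shown here, the single measured step bears on this change only loosely, as it also concerns the group at that nitrogen, and no measured compound carries a 2-methoxyphenyl. No step beyond the scatter is therefore expected in this assay, though the evidence is thin. The expected change is a 1.3-fold lower number from compound 2 to compound 3 (0.10 log units; within the scatter). For compound 3 the estimated value is 400 nM, with an expected range from 130 nM to 1200 nM.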

Compound 3, half-maximal inhibitory concentration: 280 nM
Compound 3: the middle estimate sits 1.4-fold (0.15 log units) above what was measured; measured number inside the range.
By their numbers in this assay, from the lowest: compounds 3, 1 and 2 (each within the scatter of the next).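

In this assay, the exchange of 4-fluorophenyl for 2-methoxyphenyl on the aromatic nitrogen comes out as a 1.8-fold lower number from compound 2 to compound 3 (0.25 log units; within the scatter), so this change cannot be told apart from no change at all. Methoxy in place of fluoro on an aromatic carbon comes out as a 1.1-fold lower number from compound 1 to compound 3 (0.03 log units; within the scatter), which shows that this exchange also stays inside the scatter, and all three groups tried at this nitrogen now give numbers that cannot be separated. Nothing available explains these numbers.

The compounds shown leave open whether any group on this nitrogen can move the number beyond the scatter, since all three carry a substituted phenyl and none a benzyl group or a longer alkyl chain. They also leave open what an amine or a carboxylic acid on the phenyl ring would do.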